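Swapping Methyl for Methoxy on the Sulfonyl Aryl Ring

The compounds below may be only part of what the source reports. "The series", "measured", "known", "first", "only" and "open" are said of these compounds alone.

Of the compounds shown here, three sharing one core have been tested in an assay on isolated protein for displacement of a labelled ligand from metabotropic glutamate receptor 5 (Homo sapiens), with a stated time of 60 min, tested at 1 uM; a higher number here means more inhibition at the concentration tested (going by the name of the read-out), a lower number less inhibition. Compound 1 `CC1CCN(c2c(S(=O)(=O)c3cc(F)cc(F)c3)cnc3cc(F)ccc23)CC1` gives 77%. Compound 2 `CC1CCN(c2c(S(=O)(=O)c3ccc(F)c(F)c3)cnc3cc(F)ccc23)CC1` gives 94%, and compound 3 `Cc1ccc(S(=O)(=O)c2cnc3cc(F)ccc3c2N2CCC(C)CC2)cc1C` gives 90%. Among these three numbers compound 3 stands second highest: its nearest neighbour is compound 2, a gap within the scatter, and its furthest is compound 1, a gap beyond the scatter. The two steps away from compound 1 were a number 17 percentage points higher from compound 1 to compound 2 (beyond the scatter) and a number 13 percentage points higher from compound 1 to compound 3 (beyond the scatter), while a number 4 percentage points lower from compound 2 to compound 3 (within the scatter) shows that exchanging the 3,4-difluorophenyl for the 3,4-dimethylphenyl hardly mattered.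

Compound 4 `COc1ccc(S(=O)(=O)c2cnc3cc(F)ccc3c2N2CCC(C)CC2)cc1OC` has not yet been measured. It differs from compound 3 in one place: 3,4-dimethoxyphenyl in place of 3,4-dimethylphenyl on a sulfonyl sulfur. Among the compounds with values here, no measured step involves a methoxy group, so the closest guide is a number 4 percentage points lower from compound 2 to compound 3 (within the scatter), which was within the scatter. The expected change is therefore small, a number 2 percentage points lower from compound 3 to compound 4 (within the scatter), in either direction. Compound 4 is thus expected to give 88% in this assay, with a range from 72% to 97%.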

Compound 4, a percentage reported as inhibition, at one concentration (the size of the read-out at that concentration, not a potency): 83%
The estimate for compound 4 lay 5 percentage points above the measured number; the measured number falls inside the stated range.
By their numbers in this assay, from the lowest: compounds 1, 4, 3 and 2 (each within the scatter of the next, the first and the last beyond it).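

In this assay, the only oxygen-bearing aryl group shown gives a number 7 percentage points lower from compound 3 to compound 4 (within the scatter), so 3,4-dimethoxyphenyl in place of 3,4-dimethylphenyl on a sulfonyl sulfur cannot be told apart from no change, even though the entering group adds hydrogen-bond acceptors. Set against the fluorinated groups, the same aryl group gives a number 11 percentage points lower from compound 2 to compound 4 (beyond the scatter) for the 3,4-difluorophenyl compound and a number 6 percentage points higher from compound 1 to compound 4 (within the scatter) for the 3,5-difluorophenyl compound, so only the first of these two gaps can be read as real. Nothing measured on these compounds explains why the numbers fall this way.

From the compounds shown here alone, it remains open how this position would respond to a longer chain on the oxygen, as in 3,4-diethoxyphenyl, or to an amine or a carboxylic acid on the ring. These readings come from a single concentration, so they do not give the potency of any of the compounds.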